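The source may hold more compounds than are shown below. What is called first, only, known or untested is meant among the compounds shown, and "the series" means these compounds.

Compound 1 `CCOC(=O)[C@@H]1CCCN(S(=O)(=O)c2ccc(S(=O)(=O)N(CC)C(C)C)cc2)C1` is the weaker of the two compounds for which a functional assay on MIA PaCa-2 cells (Homo sapiens) for inhibition, read by MTT assay, with a stated time of 7 days (a higher number here means a weaker inhibitor, a lower number a stronger inhibitor), returns a number: it gives 1000 nM, while compound 2 `CCN(CC)S(=O)(=O)c1ccc(S(=O)(=O)N2CCC[C@@H](C(=O)N3CC4(CCN(C(=O)OC(C)(C)C)C4)C3)C2)cc1` gives 190 nM, a lower number that lies beyond the scatter. For compound 3 `CCOC(=O)[C@@H]1CCCN(S(=O)(=O)c2ccc(S(=O)(=O)N(C)Cc3ccccc3)cc2)C1` this assay reports only a limit, > 30000 nM. The step of an at least 30-fold higher number from compound 1 to compound 3 (1.47 log units; beyond the scatter) shows that the group on the sulfonyl sulfur at that end of the core of compound 1 matters greatly, though one of the three values sits at the limit of > 30000 nM in this assay, at which 1 of the 3 values shown sits, so the true size of that step is not known.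

Compound 4 `CCOC(=O)[C@@H]1CCCN(S(=O)(=O)c2ccc(C(=O)N(CC)CC)cc2)C1` differs from compound 1 in diethylcarbamoyl in place of ethyl(isopropyl)sulfamoyl on an aromatic carbon. Among the measured compounds shown here, only the step from compound 1 to compound 3 touches the same region, and it changed the nitrogen substituents rather than the sulfonyl itself; no measured step swaps a sulfamoyl for a carbamoyl. That step was large and went toward weaker inhibition, and the same direction is expected here, though with a smaller size. The diethyl pattern of compound 4 stays close to the ethyl(isopropyl) pattern of compound 1. Compound 4 is therefore expected to give 3000 nM in this assay, between 800 nM and 15000 nM, which means an expected step of a 3.0-fold higher number from compound 1 to compound 4 (0.48 log units; beyond the scatter).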

Compound 4, half-maximal inhibitory concentration: 800 nM
Estimate against measurement, compound 4: 3.8-fold (0.57 log units) above, and the stated range covers the measured number.
By their numbers in this assay, from the lowest: compound 2; then compounds 4 and 1 (each within the scatter of the next). At a limit, above all of these: compound 3.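

The exchange of ethyl(isopropyl)sulfamoyl for diethylcarbamoyl on the aromatic carbon leaves this assay essentially unmoved, with a 1.3-fold lower number from compound 1 to compound 4 (0.10 log units; within the scatter), so a sulfonyl at this position is not needed to keep the number of compound 1. The earlier compounds had shown only that this end of the molecule can matter greatly, through compound 3, whose > 30000 nM is a limit and not a number. Nothing measured in the compounds shown accounts for the carbamoyl matching the sulfamoyl here.

Going by these compounds, it remains open whether benzyl(methyl)carbamoyl would bring the same kind of loss on the carbamoyl as benzyl(methyl)amino did on the sulfonyl sulfur. Also open, on these data alone, is whether dimethylcarbamoyl, a longer chain such as dipropylcarbamoyl, or a free amine or carboxylic acid on that aromatic carbon would stay within the scatter of compound 1.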